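Piperidine for Piperazine on the Shared Core

The source may report more compounds than this note shows. Statements on the series, on what has been measured and on what is new or still open speak of the compounds shown alone.

Of the compounds shown here, two with the same fused core have been measured. Compound 1 `CN1CCN(c2nc(Cl)nc3c2ncn3Cc2ccc(C(=O)Nc3ccccc3N)cc2)CC1` stands highest of the two numbers in a functional assay on HepG2 cells (Homo sapiens) for antiproliferative activity, read by CCK-8 assay, with a stated time of 72 h, tested at 2 uM (a higher number here means a stronger effect of the compound at the concentration tested, a lower number a weaker effect), and gives 60.4%. Compound 2 `Nc1ccccc1NC(=O)/C=C/c1ccc(Cn2cnc3c(NCc4ccccc4)nc(Cl)nc32)cc1` carries a different arrangement of the amide bearing the aminophenyl group and, in this assay, compound 2 gives 11.5%, a difference from compound 1 that lies beyond the scatter of the measurement.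

Compound 3 `CC1CCN(c2nc(Cl)nc3c2ncn3Cc2ccc(C(=O)Nc3ccccc3N)cc2)CC1` is the compound still to be measured. It differs from compound 1 in a single place: 4-methylpiperidin-1-yl in place of 4-methylpiperazin-1-yl on an aromatic carbon. Within the data shown here, no pair of measured compounds separated by one change is available, so the size of this step has to be judged without a precedent from the same series.

The account expects the step from compound 1 to compound 3 to be small, a number 5.4 percentage points lower from compound 1 to compound 3 (within the scatter), with no change beyond the scatter, since the ring size and the substituent are kept and only the second ring nitrogen of compound 1 is replaced by carbon. Compound 3 is therefore estimated at 55%, within a range from 35% to 75%.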

Compound 3, a percentage reported as inhibition, at one concentration (the size of the read-out at that concentration, not a potency): 1.22%
Compound 3: middle estimate off by 53.8 percentage points, on the high side; the whole stated range lies above it.
By their numbers in this assay, from the lowest: compound 3; then compound 2; then compound 1.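

Among these compounds, the step from the 4-methylpiperazin-1-yl group to 4-methylpiperidin-1-yl on this aromatic carbon, next to the ring nitrogen, is the first single change that can be read, and in this assay it gives a number 59.2 percentage points lower from compound 1 to compound 3 (beyond the scatter) and is large. The ring size and the 4-methyl substituent stay the same and the heavy-atom count of the group does not change, so the exchange of one ring nitrogen for carbon is enough, in this pair, to separate a clear effect at the concentration tested from a read-out close to none, which shows that this position does not accept every six-membered ring of this kind. No measurement in hand gives a reason for this step.

The compounds shown leave open whether the second ring nitrogen must carry a methyl group, as a piperazin-1-yl group with a free ring nitrogen, a 4-acetylpiperazin-1-yl group or a morpholin-4-yl group at the same carbon would test. They also leave open whether the step would keep its size on a full concentration series, since this assay gives a read-out at one concentration and not a potency.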